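The source may hold more compounds than are shown below. What is called first, only, known or untested is meant among the compounds shown, and "the series" means these compounds.

Measured in a functional assay on HeLa cells (Homo sapiens) for antiproliferative activity, read by sulforhodamine B assay, with a stated time of 48 h; a higher number here means a weaker inhibitor, a lower number a stronger inhibitor:
- compound 1 `COc1ccc2nc(-c3ccc(N/C=C\C(=O)c4ccc(OC)c(O)c4)c(C)c3)sc2c1`: 12000 nM
- compound 2 `COc1ccc2nc(-c3ccc(N/C=C\C(=O)c4cc(OC)c(OC)c(OC)c4)c(C)c3)sc2c1`: 16100 nM
- compound 3 `COc1ccc2nc(-c3ccc(N/C=C\C(=O)c4ccc(OC)c([N+](=O)[O-])c4)c(C)c3)sc2c1`: 17600 nM

These three values lie within the usual scatter of one another, so compound 3, at 17600 nM, cannot be ranked against the other two.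

Compound 4 `COc1ccc2nc(-c3ccc(N/C=C\C(=O)c4cc(OC)c(OC)c([N+](=O)[O-])c4)c(C)c3)sc2c1` is compound 3 with one addition: methoxy in place of hydrogen on an aromatic carbon, ortho to a methoxy group and meta to a nitro group (methoxy in place of hydrogen on an aromatic carbon).

Within the data shown here, only one measured step changes a single place: a 1.5-fold higher number from compound 1 to compound 3 (0.17 log units; within the scatter). That step puts nitro in place of hydroxy, a different swap, so it bears on the new change only indirectly, and it shows no shift beyond the scatter. Among the measured compounds shown here, no measured pair shows a methoxy being added on its own. The closest evidence is that compound 3 carries fewer methoxy groups than compound 2, which gives 16100 nM, and these two values are within the scatter of each other.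

No step beyond the scatter is therefore expected in this assay. The expected change is small: a 1.1-fold lower number from compound 3 to compound 4 (0.04 log units; within the scatter). The estimate for compound 4 is 16000 nM, with an expected range from 9000 nM to 30000 nM.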

Compound 4, half-maximal inhibitory concentration: 12100 nM
For compound 4 the middle estimate is 1.3-fold (0.12 log units) above the measured one; low and high end bracket the measured number.
By their numbers in this assay, from the lowest: compounds 1, 4, 2 and 3 (each within the scatter of the next).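

In this assay, the addition of methoxy on the aromatic carbon ortho to a methoxy group and meta to a nitro group can now be read directly (a 1.5-fold lower number from compound 3 to compound 4 (0.16 log units; within the scatter)), and the step stays within the scatter, so this carbon carries the extra group with no measurable shift in antiproliferative potency. The result also gives a second single-place comparison, in which nitro stands in place of methoxy on an aromatic carbon (a 1.3-fold lower number from compound 2 to compound 4 (0.12 log units; within the scatter)), and this step is within the scatter too, so neither change moves the number by more than repeated measurements would. No measurement here offers an explanation for these small steps.

Every single-place step among these compounds stays within the scatter, so it remains open whether any group on this ring can shift the number in a way that can be read. An amine, a carboxylic acid or a longer chain such as propoxy on this same carbon would test whether it tolerates groups very different from methoxy.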